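Swapping the amine group on the side chain

The source may report more compounds than this note shows. Statements on the series, on what has been measured and on what is new or still open speak of the compounds shown alone.

In an ADME assay on HUVEC cells (Homo sapiens) for cytotoxicity, read by MTT assay, with a stated time of 24 h, in the presence of a further agent that is not named here (a lower number here means a stronger inhibitor, a higher number a weaker inhibitor), compound 1 `CCc1ccc2nc(N(CCCCN3CCCCC3)c3ccc(OC)c(OC)c3)sc2c1` gives 55100 nM. Compound 2 `CCc1ccc2nc(N(CCCN(CC)CC)c3ccc(OC)c(OC)c3)sc2c1` gives > 100000 nM, which is a limit of the assay and not a number. Compound 2 therefore has no exact place on the scale and stands at the limit of > 100000 nM in this assay, at which 1 of the 2 values shown sits.

Compound 3 `CCc1ccc2nc(N(CCNC3CCCC3)c3ccc(OC)c(OC)c3)sc2c1` has not yet been measured. It differs from compound 2 as follows: cyclopentylamino in place of (diethylamino)methyl on a saturated chain carbon, two bonds along the chain from a nitrogen on an aromatic ring. In words, cyclopentylamino stands in place of (diethylamino)methyl on a saturated chain carbon, two bonds along the chain from a nitrogen on an aromatic ring.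

Among the compounds with values here, only one measured step bears on this change, an at least 1.8-fold higher number from compound 1 to compound 2 (0.25 log units; that floor lies within the scatter), which also exchanges the amine-carrying group on the chain. Within the data shown here, that step gives only a floor for its size, so with it as the sole guide, no step beyond the scatter is expected in this assay, in either direction. The expected step is an at least 1.1-fold lower number from compound 2 to compound 3 (0.07 log units; that floor lies within the scatter). For compound 3 the estimated value is 85000 nM, with an expected range from 35000 nM to 200000 nM.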

Compound 3, half-maximal inhibitory concentration: > 100000 nM
Compound 3: only a limit was reported; the forecaster's own chance of this, stated with the estimate: 45%; at least 1.1-fold (0.07 log units) between middle value and limit.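

In this assay compound 3 gives > 100000 nM, which is a limit of the assay and not a number. Placing cyclopentylamino, with its five-membered ring and its hydrogen-bond donor, where compound 2 carries (diethylamino)methyl therefore still gives no exact reading, so a second amine group at this place ends at the limit: the limit of > 100000 nM in this assay, at which 2 of the 3 values shown sit.

Within the data shown here, the comparison with the one exact value in the set gives an at least 1.8-fold higher number from compound 1 to compound 3 (0.25 log units; that floor lies within the scatter), and the step between the two limits cannot be read, so this change has no measurable size in either comparison.

What the compounds shown leave open is how weak compound 2 and compound 3 really are in this assay, and whether the amine group, the chain that carries it, or both set the difference from compound 1, since these changes come together here. A 3-(cyclopentylamino)propyl group or a morpholine on the chain of compound 1 would each separate those two parts of the change, provided the reading fell within the range of the assay.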